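A few compounds are considered here, and "the series" means these few. Any claim that something is new, unique, unknown or untested is made for them only; others in the source may bear on it.

Measured so far in a functional assay on A549 cells (Homo sapiens) for cytotoxicity, read by MTT assay, with a stated time of 72 h; on this read-out lower numbers stand for stronger inhibition and higher numbers for weaker inhibition
Compound 1 `CCOC(=O)c1c(C)oc2ncnc(Nc3ccc(OCc4cccc(Cl)c4)cc3)c12` gives 513000 nM as a number
Compound 2 `CCOC(=O)c1c(C)oc2ncnc(Nc3ccccc3)c12` gives > 1000000 nM as a limit

Compound 2 stands only at > 1000000 nM which is a limit and not a number. Compound 3 `CCOC(=O)c1c(C)oc2ncnc(Nc3ccc(OCc4ccc(C)cc4)cc3)c12` differs from it by (4-methylbenzyl)oxy in place of hydrogen on an aromatic carbon with (4-methylbenzyl)oxy in place of hydrogen on an aromatic carbon, para to a large group. For the measured compounds named here, the one measured step that bears on this is an at least 1.9-fold higher number from compound 1 to compound 2 (0.28 log units; that floor lies within the scatter) and its floor lies within the scatter. Going by the values given here, compound 1, carrying (3-chlorobenzyl)oxy, gives 513000 nM in this assay and is the only guide. The expected step is an at least 2.0-fold lower number from compound 2 to compound 3 (0.30 log units; that floor lies within the scatter) as a small move to a lower number, perhaps no larger than the scatter. Compound 3 is expected at 500000 nM with an estimated range from 200000 nM to 1000000 nM in this read-out.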

Compound 3, half-maximal inhibitory concentration: > 1000000 nM
Compound 3: a limit, no number; the forecaster's own chance of this, stated with the estimate: 25%; middle value at least 2.0-fold (0.30 log units) away from the limit.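

In this assay compound 3 gives > 1000000 nM, a limit and not a number. For the compounds shown here, the one readable step is an at least 1.9-fold higher number from compound 1 to compound 3 (0.28 log units; that floor lies within the scatter), with 4-methylphenyl in place of 3-chlorophenyl, so a substituted benzyl ether on this aromatic carbon does not by itself yield a number. The step between compound 2 and compound 3 cannot be read, and most of the series now stands at one limit: the limit of > 1000000 nM in this assay, at which 2 of the 3 values shown sit.

Open, from the compounds shown here alone, is whether an amine or a carboxylic acid on that benzyl ring gives a number in this assay. Also open, going by these compounds, is whether compound 3 truly differs from compound 1 by more than the scatter.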